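Bromo for cyano at the chain end of compound 3

This account rests on a few compounds, and the source may have more. Where it says the series, first, only, none or still open, it means among the compounds named here.

Measured compounds in an assay for inhibition of Fatty-acid amide hydrolase 1 (Rattus norvegicus), using a Dixon plot; a higher number here means a weaker inhibitor, a lower number a stronger inhibitor:
compound 1 `O=C(CCCCCCc1ccccc1)c1ncc(-c2ccc(CCl)cn2)o1` gives 22.4 nM
compound 2 `O=CCCCCc1cnc(C(=O)CCCCCCc2ccccc2)o1` gives 14.6 nM
compound 3 `N#CCCCCCc1cnc(C(=O)CCCCCCc2ccccc2)o1` gives 4.8 nM

Compound 3 holds the lowest number of the three, with compound 2 nearest and compound 1 furthest, both steps beyond the scatter. Compound 4 `O=C(CCCCCCc1ccccc1)c1ncc(CCCCCBr)o1` differs from compound 3 by bromo in place of cyano on a saturated chain carbon, five bonds along the chain from an aromatic carbon. The step that bears on it most directly is a 3.0-fold lower number from compound 2 to compound 3 (0.48 log units; beyond the scatter), which shows the nitrile end doing somewhat better than the aldehyde end on the same chain. The chlorine-bearing compound 1 sits at the other end of the range, with a 4.7-fold lower number from compound 1 to compound 3 (0.67 log units; beyond the scatter) and a 1.5-fold lower number from compound 1 to compound 2 (0.19 log units; within the scatter), though the halogen there sits on a different group, so its weight is limited. Taking away the nitrile is therefore expected to cost some of the gain seen from compound 2 to compound 3, a modest rise in this assay rather than a large one. For compound 4 the estimate is 12 nM, within 5 nM to 30 nM, which means an expected step of a 2.5-fold higher number from compound 3 to compound 4 (0.40 log units; beyond the scatter).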

Compound 4, inhibition constant: 6.1 nM
Estimate against measurement, compound 4: 2.0-fold (0.29 log units) above, and the stated range covers the measured number.
By their numbers in this assay, from the lowest: compounds 3 and 4 (each within the scatter of the next); then compounds 2 and 1 (each within the scatter of the next).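

In this assay, cyano and bromo at this chain end cannot be told apart (a 1.3-fold higher number from compound 3 to compound 4 (0.10 log units; within the scatter)), so the triple bond and the hydrogen-bond acceptor that leave with cyano are not needed to keep the number at this level. The aldehyde-ended compound and the compound with the chlorine-bearing ring both stand apart from the bromo compound (a 2.4-fold lower number from compound 2 to compound 4 (0.38 log units; beyond the scatter); a 3.7-fold lower number from compound 1 to compound 4 (0.56 log units; beyond the scatter)), so compound 2 and compound 1 now each have two chain-ended neighbours with lower numbers, not one. Nothing shown accounts for the match between bromo and cyano.

As far as these compounds go, whether the chain end tolerates any group or only some remains open, and an amine or a carboxylic acid at that carbon would test this. Chloro or iodo on the same chain would show whether bromo is a special case among halogens.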